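Acetyl in place of the chlorohydroxypropyl chain

This account rests on a few compounds, and the source may have more. Where it says the series, first, only, none or still open, it means among the compounds named here.

In a functional assay (Homo sapiens) (on this read-out lower numbers stand for stronger inhibition and higher numbers for weaker inhibition), compound 1 (`OC(CCl)CNc1nc2ccnc(-c3cccc(C(F)(F)F)c3)n2n1`) gives 9300 nM, and one further entry offers no single number. Compound 3 (`CC(=O)Nc1nc2ccnc(-c3cccc(C(F)(F)F)c3)n2n1`) is still unmeasured and carries acetyl in place of 3-chloro-2-hydroxypropyl on a nitrogen on an aromatic ring. Among the measured compounds shown here, no measured step covers this change. With a different group on that nitrogen, compound 2 (`CNc1nc2ccnc(-c3cccc(C(F)(F)F)c3)n2n1`) gives 10200 nM; 10200 nM (2 entries), within the usual scatter of compound 1, so no shift beyond the scatter is expected in this assay, in either direction. The expected move is a 1.1-fold higher number from compound 1 to compound 3 (0.03 log units; within the scatter). The estimate for compound 3 is 10000 nM, with a range of 3500 nM to 28000 nM.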

Compound 3, half-maximal inhibitory concentration: 20000 nM
For compound 3 the middle estimate is 2.0-fold (0.30 log units) below the measured one, and the stated range covers the measured number.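

In this assay, acetyl in place of 3-chloro-2-hydroxypropyl on this nitrogen brings a 2.2-fold higher number from compound 1 to compound 3 (0.33 log units; beyond the scatter) and so weakens inhibition modestly, which shows that the position is not indifferent to its substituent, as compound 2 alone left it looking. The step is small, and no available data bear on its cause.

Open, going by these compounds, is whether a carboxylic acid or a longer chain ending in an amine on this nitrogen would shift the number further, and in which direction.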